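The compounds below may be only part of what the source reports. "The series", "measured", "known", "first", "only" and "open" are said of these compounds alone.

Three compounds share one core and differ only in the group at the far end of the sulfonamide. Compound 1 `COc1ccc(N2C[C@@H](C)N[C@@H](C)C2)cc1NS(=O)(=O)c1ccc(-c2cc(Cl)ccc2F)cc1` gives 0.501 nM in a functional assay for agonist activity at growth hormone secretagogue receptor type 1 (Homo sapiens), read by FLIPR; on this read-out lower numbers stand for an effect already at smaller amounts and higher numbers for an effect only at larger amounts of compound. Compound 2 `COc1ccc(N2C[C@@H](C)N[C@@H](C)C2)cc1NS(=O)(=O)c1ccc(-c2ccncc2)cc1` gives 316 nM in this assay, and compound 3 `COc1ccc(N2C[C@@H](C)N[C@@H](C)C2)cc1NS(=O)(=O)c1ccc(-c2cncnc2)cc1` gives 316 nM. Compound 3 thus stands level with compound 2, the two together showing the highest numbers of the three and lying far from compound 1: a 630-fold higher number from compound 1 to compound 3 (2.80 log units; beyond the scatter), while no change at the digits printed from compound 2 to compound 3 (within the scatter).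

Compound 4 `COc1ccc(N2C[C@@H](C)N[C@@H](C)C2)cc1NS(=O)(=O)c1ccc(N2CCCC2=O)cc1` is still unmeasured; it differs from compound 3 in that (2-oxopyrrolidin-1-yl in place of pyrimidin-5-yl on an aromatic carbon). Going by the values given here, no measured step involves a non-aromatic ring at this position, so the known steps bear on it only indirectly: a 630-fold higher number from compound 1 to compound 2 (2.80 log units; beyond the scatter) and a 630-fold higher number from compound 1 to compound 3 (2.80 log units; beyond the scatter) show that giving up the substituted phenyl costs a great deal, and no change at the digits printed from compound 2 to compound 3 (within the scatter) shows that exchanging one small heterocycle for another leaves the number where it was. Compound 4 is therefore expected to stay near that weaker level, the expected step being a 1.6-fold higher number from compound 3 to compound 4 (0.20 log units; within the scatter). The estimate for compound 4 is 500 nM, with a range from 100 nM to 3000 nM.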

Compound 4, half-maximal effective concentration: 39.8 nM
The estimate for compound 4 lay 13-fold (1.10 log units) above the measured number; measured number outside the range, below it.
By their numbers in this assay, from the lowest: compound 1; then compound 4; then compounds 2 and 3 (each within the scatter of the next).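

In this assay, the step of a 7.9-fold lower number from compound 3 to compound 4 (0.90 log units; beyond the scatter) and the step of a 7.9-fold lower number from compound 2 to compound 4 (0.90 log units; beyond the scatter) show that this position does not need an aromatic ring to give a lower number than the two aromatic heterocycles, and 2-oxopyrrolidin-1-yl achieves this with the same number of heavy atoms as pyrimidin-5-yl. It does not close the gap to the substituted phenyl, however, as the step of a 79-fold higher number from compound 1 to compound 4 (1.90 log units; beyond the scatter) is still large. No measurement at hand explains either step.

The compounds shown leave open whether the gain depends on the carbonyl of the ring, which a plain pyrrolidine ring without that carbonyl would test. They also leave open whether a morpholine ring or an open-chain amide such as acetamide would behave like 2-oxopyrrolidin-1-yl.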